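This account rests on a few compounds, and the source may have more. Where it says the series, first, only, none or still open, it means among the compounds named here.

Working notes on the series. The core is shared by compound 1 `COc1cc(N2C(N)=C(C#N)C(c3c(O)ccc4ccccc34)C3=C2CC(C)(C)CC3=O)cc(OC)c1OC` and compound 2 `COc1cc(N2C(N)=C(C#N)C(c3ccc(Cl)cc3Cl)C3=C2CC(C)(C)CC3=O)cc(OC)c1OC`; in a functional assay on Ehrlich cells (Mus musculus) for cytotoxicity, tested at 100 ug/mL (on this read-out lower numbers stand for a weaker effect and higher numbers for a stronger effect at the one concentration tested), compound 1 gives 90% and compound 2 gives 100%. On these two numbers compound 2 stands highest, with compound 1 nearest, and the step of a number 10 percentage points higher from compound 1 to compound 2 (within the scatter) does not separate them.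

Compound 3 `COc1cc(N2C(N)=C(C#N)C(c3cccc([N+](=O)[O-])c3)C3=C2CC(C)(C)CC3=O)cc(OC)c1OC` is the next member. Relative to compound 2 it changes in one place: 3-nitrophenyl in place of 2,4-dichlorophenyl on a saturated ring carbon. Going by the values given here, the only measured step at the same saturated ring carbon, a number 10 percentage points higher from compound 1 to compound 2 (within the scatter), came with a change of aryl group and stayed within the scatter, so no measured step argues for a move beyond the scatter here either. Compound 3 is therefore expected to sit close to compound 2, with the step of a number 10 percentage points lower from compound 2 to compound 3 (within the scatter) expected to fall within the scatter. For compound 3 in this assay the estimate is 90%, with a range from 70% to 100%.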

Compound 3, a percentage reported as activity, at one concentration (the size of the read-out at that concentration, not a potency): 30%
Beside the measured number, compound 3's estimate is 60 percentage points above it; measured number below the stated range.
By their numbers in this assay, from the lowest: compound 3; then compounds 1 and 2 (each within the scatter of the next).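

In this assay the saturated ring carbon proves sensitive to the aryl group it carries: 3-nitrophenyl in place of 2,4-dichlorophenyl gives a number 70 percentage points lower from compound 2 to compound 3 (beyond the scatter) and 3-nitrophenyl in place of 2-hydroxynaphthalen-1-yl gives a number 60 percentage points lower from compound 1 to compound 3 (beyond the scatter) in the same read-out. The earlier pair suggested tolerance at this carbon, but that holds only for 2,4-dichlorophenyl and 2-hydroxynaphthalen-1-yl, and compound 3 goes against it. Nothing at hand accounts for the drop.

Open, from the compounds shown here alone, is whether the drop follows the nitro group itself or the absence of the chlorines. A plain phenyl at this carbon, or an amine or a carboxylic acid in place of the nitro group on the phenyl ring, would help separate these readings.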